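Chloro to methoxy on the acetamide chain of compound 1

The source may hold more compounds than are shown below. What is called first, only, known or untested is meant among the compounds shown, and "the series" means these compounds.

Compound 1 `COc1ccc(CN(C(=O)CCl)c2cc(OC)c(OC)c(OC)c2)cc1O` is tested in a functional assay on HCT-116 cells (Homo sapiens) for inhibition, read by MTT assay, with a stated time of 48 h (a lower number here means a stronger inhibitor, a higher number a weaker inhibitor), where compound 1 gives 250 nM, the lowest of the two numbers recorded. Compound 2 `COc1ccc(CNc2cc(OC)c(OC)c(OC)c2)cc1C` gives 60900 nM in this assay, a gap to compound 1 that lies well beyond the scatter. Compound 3 `COc1cc(NCc2ccccc2)cc(OC)c1OC` reaches only the limit of this assay, > 80000 nM, and no number is recorded for it (the limit of > 80000 nM in this assay, at which 1 of the 3 values shown sits). Compound 4 `COCC(=O)N(Cc1ccc(OC)c(O)c1)c1cc(OC)c(OC)c(OC)c1` is not yet measured; it differs from compound 1 by methoxy in place of chloro on a saturated chain carbon bound to a carbonyl carbon. For the measured compounds named here, no step between measured compounds covers this change. The expectation is a weaker inhibitor, with a step of a 20-fold higher number from compound 1 to compound 4 (1.30 log units; beyond the scatter) in this assay. For compound 4 the estimate in this assay is 5000 nM, in a range from 800 nM to 40000 nM.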

Compound 4, half-maximal inhibitory concentration: 230 nM
Compound 4: middle estimate off by 22-fold (1.34 log units), on the high side; measured number below the stated range.
By their numbers in this assay, from the lowest: compounds 4 and 1 (each within the scatter of the next); then compound 2. At a limit, above all of these: compound 3.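

In this assay, methoxy in place of chloro on a saturated chain carbon bound to a carbonyl carbon gives a 1.1-fold lower number from compound 1 to compound 4 (0.04 log units; within the scatter) and leaves the number unmoved within the scatter. In this pair, then, the chloro is not required for a number at this level. Nothing measured here offers a cause for this.

As far as these compounds go, how a dimethylamino group or a longer chain would read at this carbon stays open. From the compounds shown here alone, the part played by the whole acylated chain also stays open, since compound 2 differs from compound 1 in more than one place.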